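The source may report more compounds than this note shows. Statements on the series, on what has been measured and on what is new or still open speak of the compounds shown alone.

Working notes on the series.

Compound 2 `Cc1ccc2c(c1)/C(=C1/S/C(=N/c3ccc(S(N)(=O)=O)cc3)NC1=O)C(=O)N2` is the methyl member. In a functional assay on MCF7 cells (Homo sapiens) for antiproliferative activity, read by MTT assay (on this read-out higher numbers stand for weaker inhibition and lower numbers for stronger inhibition), compound 2 gives only a limit, > 200000 nM, and no number. Compound 1 `NS(=O)(=O)c1ccc(/N=C2\NC(=O)/C(=C3/C(=O)Nc4ccc([N+](=O)[O-])cc43)S2)cc1` carries a nitro where compound 2 carries the methyl. In this assay compound 1 likewise gives only a limit, > 200000 nM. Among the measured compounds shown here, the single step so far, a step that the two limits leave unreadable from compound 1 to compound 2, cannot be read because the limit of > 200000 nM in this assay, at which 2 of the 2 values shown sit, holds both values; it shows neither direction nor size, only that neither compound reaches a measurable potency within the tested range.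

Compound 3 `COc1ccc2c(c1)/C(=C1/S/C(=N/c3ccc(S(N)(=O)=O)cc3)NC1=O)C(=O)N2` follows from compound 2 by methoxy in place of methyl on an aromatic carbon. For the measured compounds named here, no measured step in this assay speaks directly to a methoxy for methyl exchange; the only step available, a step that the two limits leave unreadable from compound 1 to compound 2, is unreadable, so it gives no direction to carry over. With both measured compounds sitting at the limit, compound 3 is expected to remain there as well, the step of a number no higher from compound 2 to compound 3 (the limit leaves the size open) being an estimate without a measured basis. Compound 3 is therefore estimated at 200000 nM, within 50000 nM to 1000000 nM, with the likeliest outcome being another limit rather than a number.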

Compound 3, half-maximal inhibitory concentration: 125000 nM
Estimate against measurement, compound 3: 1.6-fold (0.20 log units) above, and the stated range covers the measured number.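

In this assay compound 3 is the only one of the three that gives a number, 125000 nM, so methoxy is the one group shown at this aromatic carbon that brings a value within the measurable range. On the same carbon, methoxy in place of methyl gives an at least 1.6-fold lower number from compound 2 to compound 3 (0.20 log units; that floor lies within the scatter), and methoxy in place of nitro gives an at least 1.6-fold lower number from compound 1 to compound 3 (0.20 log units; that floor lies within the scatter). Each step is only a floor, and its true size stays open because the other two values are limits: the limit of > 200000 nM in this assay, at which 2 of the 3 values shown sit.

On these data alone, whether compound 3 truly stands beyond the scatter from compound 1 and compound 2 remains open, and so does how a hydroxyl, an amine or a longer chain such as ethoxy would read on this carbon. As far as these compounds go, all three compounds keep the rest of the shared core unchanged, so the effect of a change elsewhere on the core is also open.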